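From compound 3 to compound 4 at the limit

The compounds below may be only part of what the source reports. "The series", "measured", "known", "first", "only" and "open" are said of these compounds alone.

In a functional assay on cells (leukaemia cell line, Homo sapiens) for inhibition, read by sulforhodamine B assay, with a stated time of 48 h (a lower number here means that less compound is tolerated, a higher number that more compound is tolerated), compound 1 (`O=S(=O)(Nc1ccccc1Cl)c1ccc(-c2cnc(C3CC3)o2)cc1`) gives > 100000 nM as a limit. Compound 2 (`O=S(=O)(Nc1ccc(Br)c(Cl)c1)c1ccc(-c2cnc(C3CC3)o2)cc1`) gives > 100000 nM as a limit. Compound 3 (`COc1cc(NS(=O)(=O)c2ccc(-c3cnc(C4CC4)o3)cc2)ccc1F`) gives > 100000 nM as a limit, so it has no number of its own. Going by the values given here, all three compounds share the limit of > 100000 nM in this assay, at which 3 of the 3 values shown sit, as their only reading.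

The next change is 3-chloro-4-iodophenyl in place of 4-fluoro-3-methoxyphenyl on a sulfonamide nitrogen and gives compound 4 (`O=S(=O)(Nc1ccc(I)c(Cl)c1)c1ccc(-c2cnc(C3CC3)o2)cc1`), with 3-chloro-4-iodophenyl in place of 4-fluoro-3-methoxyphenyl on a sulfonamide nitrogen.

The measured swaps at this nitrogen give no size to carry over: (a step that the two limits leave unreadable from compound 1 to compound 2), (a step that the two limits leave unreadable from compound 1 to compound 3) and (a step that the two limits leave unreadable from compound 2 to compound 3). With every reading at the limit of > 100000 nM in this assay, at which 3 of the 3 values shown sit, in this series, no step beyond the scatter and no direction can be argued for this assay, and compound 4 is expected to stay at the limit.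

The expected outcome is a number no higher from compound 3 to compound 4 (the limit leaves the size open) with no direction attached. Compound 4 is estimated at 100000 nM with an expected range from 40000 nM to 200000 nM if a number is reported at all.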

Compound 4, concentration lethal to 50% of the cells: > 100000 nM
Compound 4 ended at the assay's limit (the forecaster's own chance of this, stated with the estimate: 85%); the middle value sits exactly at the limit.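

Compound 4 reads only as a limit in this assay, so no step from compound 1, compound 2 or compound 3 to compound 4 can be read: the limit of > 100000 nM in this assay, at which 4 of the 4 values shown sit.

The compounds shown leave open whether any group on a sulfonamide nitrogen gives a number rather than a limit, and how large such a step would be.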